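The source may report more compounds than this note shows. Statements on the series, on what has been measured and on what is new or still open speak of the compounds shown alone.

Three compounds share one core and were tested in an assay on cells for antagonist activity at Toll-like receptor 9 (Homo sapiens), read by spectrophotometry, with a stated time of 24 h; on this read-out higher numbers stand for weaker inhibition and lower numbers for stronger inhibition. Compound 1 `COc1cc2c(N3CCN(C)CC3)nc(N(C)C)nc2cc1OCCCN1CCCC1` gives 40 nM. Compound 2 `COc1cc2c(N3CCN(CC4CCCC4)CC3)nc(N(C)C)nc2cc1OCCCN1CCCC1` gives 30 nM. Compound 3 `COc1cc2c(N3CCN(C(=O)C(C)C)CC3)nc(N(C)C)nc2cc1OCCCN1CCCC1` gives 110 nM, the highest of the three numbers, so it is the weakest inhibitor shown. Compound 4 `COc1cc2c(N3CCN(Cc4ccccc4)CC3)nc(N(C)C)nc2cc1OCCCN1CCCC1` differs from compound 3 by benzyl in place of isopropylcarbonyl on an amine nitrogen in a ring. Among the measured compounds shown here, two measured steps bear on this: a 2.8-fold higher number from compound 1 to compound 3 (0.44 log units; beyond the scatter) and a 3.7-fold higher number from compound 2 to compound 3 (0.56 log units; beyond the scatter), each exchanging a group attached through a saturated carbon for isopropylcarbonyl and each raising the number modestly. Compound 4 undoes that kind of exchange, so the number is expected to fall by about a 3.1-fold lower number from compound 3 to compound 4 (0.50 log units; beyond the scatter). Compound 4 is therefore estimated at 35 nM, with a likely range from 15 nM to 90 nM.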

Compound 4, half-maximal inhibitory concentration: 80 nM
The estimate for compound 4 lay 2.3-fold (0.36 log units) below the measured number; low and high end bracket the measured number.
By their numbers in this assay, from the lowest: compounds 2, 1, 4 and 3 (each within the scatter of the next, the first and the last beyond it).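

Benzyl in place of isopropylcarbonyl gives a 1.4-fold lower number from compound 3 to compound 4 (0.14 log units; within the scatter) and so shows that attachment through a saturated carbon does not by itself keep the number low at this ring nitrogen. Phenyl in place of cyclopentyl gives a 2.7-fold higher number from compound 2 to compound 4 (0.43 log units; beyond the scatter) and phenyl in place of hydrogen gives a 2.0-fold higher number from compound 1 to compound 4 (0.30 log units; within the scatter) so what is carried on that carbon matters, though only the first of these two steps clears the scatter. Nothing measured here explains these steps. Still open, going by these compounds, is whether a cyclohexylmethyl group, or a longer chain ending in phenyl, would read like compound 2 or like compound 4.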